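This account rests on a few compounds, and the source may have more. Where it says the series, first, only, none or still open, it means among the compounds named here.

Measured so far in a physicochemical assay for solubility, measured as kinetic solubility; a lower number here means a less soluble compound, a higher number a more soluble compound:
- compound 1 `O=C(Nc1ccnnc1)c1cc(C(F)(F)F)ccc1OCc1ccccc1` gives < 1000 nM, a limit of the assay and not a number
- compound 2 `O=C(Nc1ccnnc1)c1cc(N2CCCC2)ccc1OCc1ccccc1` gives 35000 nM

Going by the values given here, compound 2 holds the only true number, 35000 nM, so its standing rests on a single comparison. Compound 1 stands at the limit of < 1000 nM in this assay, at which 1 of the 2 values shown sits. Among the compounds with values here, the one measured step, an at least 35-fold higher number from compound 1 to compound 2 (1.54 log units; beyond the scatter), put pyrrolidin-1-yl in place of trifluoromethyl on an aromatic carbon and was large, beyond the scatter.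

Compound 3 `CN1CC2(C1)CN(c1ccc(OCc3ccccc3)c(C(=O)Nc3ccnnc3)c1)C2` carries a group of 8 heavy atoms (6 carbon, 2 nitrogen; 2 four-membered non-aromatic rings with 1 hetero atom each) in place of a group of 5 heavy atoms (4 carbon, 1 nitrogen; one five-membered non-aromatic ring with 1 hetero atom), on an aromatic carbon, meta to a (pyridazin-4-yl)carbamoyl group and para to a benzyloxy group. The measured step concerns the same aromatic carbon but a different exchange, and it starts from a limit, so it guides the direction only loosely. Here one non-aromatic ring group replaces another, and a much smaller move in this assay is expected, slightly upward and not clearly beyond the scatter. The expected step is a 1.7-fold higher number from compound 2 to compound 3 (0.23 log units; within the scatter). For compound 3 the estimated value is 60000 nM, with an expected range from 25000 nM to 140000 nM.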

Compound 3, solubility: 198000 nM
Compound 3: middle estimate off by 3.3-fold (0.52 log units), on the low side; measured number outside the range, above it.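

In this assay, the aromatic carbon meta to the (pyridazin-4-yl)carbamoyl group and para to the benzyloxy group still shows a clear response when one non-aromatic ring group replaces another, with a 5.7-fold higher number from compound 2 to compound 3 (0.75 log units; beyond the scatter). Going by these compounds alone, this is the first step at this position with true numbers at both ends, whereas the earlier step left trifluoromethyl and started from a limit. The step of an at least 190-fold higher number from compound 1 to compound 3 (2.29 log units; beyond the scatter) is larger still, but its starting point is a limit and not a number, so its size is only a floor: the limit of < 1000 nM in this assay, at which 1 of the 3 values shown sits.

The group with 2 four-membered non-aromatic rings differs from pyrrolidin-1-yl in ring size, in heavy atoms and in nitrogen content all at once, and the compounds shown do not tell these changes apart. On these data alone, how a plain azetidin-1-yl, a morpholin-4-yl or a 4-methylpiperazin-1-yl group on the same aromatic carbon would read in this assay stays open, and with it whether the second nitrogen or the four-membered rings go with the higher number.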